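The source may hold more compounds than are shown below. What is called first, only, known or untested is meant among the compounds shown, and "the series" means these compounds.

Measured in a functional assay on U-87MG ATCC cells for antiproliferative activity against U-87 MG (Homo sapiens), read by MTT assay, with a stated time of 48 h; on this read-out lower numbers stand for stronger inhibition and higher numbers for weaker inhibition:
- Compound 1 `COc1ccc(-c2nc(C)c(C(=O)CSc3nc(-c4ccc(Cl)cc4)c(C#N)c(=O)[nH]3)s2)cc1`: 45900 nM
- Compound 2 `Cc1nc(-c2ccccc2)sc1C(=O)CSc1nc(-c2cccc(Cl)c2)c(C#N)c(=O)[nH]1`: 28200 nM
- Compound 3 `COc1ccc(-c2nc(C)c(C(=O)CSc3nc(-c4ccc(Cl)c(Cl)c4)c(C#N)c(=O)[nH]3)s2)cc1`: 68500 nM

Compound 3 stands level with compound 1 within the scatter, and its number is higher than that of compound 2 beyond the scatter. Compound 4 `COc1ccc(-c2nc(C)c(C(=O)CSc3nc(-c4cccc(Cl)c4)c(C#N)c(=O)[nH]3)s2)cc1` follows from compound 3 by one change, hydrogen in place of chloro on an aromatic carbon, 3,4-dichlorophenyl to 3-chlorophenyl: hydrogen in place of chloro on an aromatic carbon.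

Among the compounds with values here, one measured step bears directly on this exchange: a 1.5-fold higher number from compound 1 to compound 3 (0.17 log units; within the scatter). It is the same kind of exchange run the other way, though at the other chloro group, and it stayed small. Compound 2 carries the same 3-chlorophenyl group but differs elsewhere, and its value offers only a loose guide. A small step toward a lower number is therefore expected, no larger than the scatter.

The expected change is a 1.6-fold lower number from compound 3 to compound 4 (0.21 log units; within the scatter). Compound 4 is estimated at 42000 nM, with an expected range from 20000 nM to 85000 nM.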

Compound 4, half-maximal inhibitory concentration: 78900 nM
Estimate against measurement, compound 4: 1.9-fold (0.27 log units) below, and the stated range covers the measured number.
By their numbers in this assay, from the lowest: compounds 2, 1, 3 and 4 (each within the scatter of the next, the first and the last beyond it).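

In this assay, taking away the chloro group para to a large group, so that 3,4-dichlorophenyl becomes 3-chlorophenyl, gives a 1.2-fold higher number from compound 3 to compound 4 (0.06 log units; within the scatter), and this position shows no readable response to chloro or hydrogen when the other chloro group stays in place. Within the data shown here, exchanging 4-chlorophenyl for 3-chlorophenyl gives a 1.7-fold higher number from compound 1 to compound 4 (0.24 log units; within the scatter), so the placing of the single chloro group cannot be read as mattering here either, whereas adding a methoxy group, with 3-chlorophenyl held constant, gives a 2.8-fold higher number from compound 2 to compound 4 (0.45 log units; beyond the scatter), the only one of these steps beyond the scatter. No measurement shown accounts for these differences.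

As far as these compounds go, it remains open whether an amine, a hydroxyl or a carboxylic acid in place of chloro would move the number beyond the scatter. The methoxy step is also a single pair, so whether it holds with other aryl groups is unsettled.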